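Chain extension at the side-chain branch point

This account rests on a few compounds, and the source may have more. Where it says the series, first, only, none or still open, it means among the compounds named here.

Compound 1 `CC(CCO)n1cnc2c(Cl)ncnc21` and compound 2 `CCC(CCO)n1cnc2c(Cl)ncnc21` share one core, while compound 3 `CCCCC(CCO)n1cnc2c(Cl)nc(F)nc21` carries another; the difference between the two cores is not broken down here. In a functional assay on HCT-116 cells (Homo sapiens) for antiproliferative activity, read by MTT assay, with a stated time of 48 h (a lower number here means a stronger inhibitor, a higher number a weaker inhibitor), compound 1 gives only a limit, > 50000 nM. Compound 2 likewise reaches only a limit, > 50000 nM. For the measured compounds named here, compound 3 gives 13500 nM, the sole number among the measured compounds. The step that the two limits leave unreadable from compound 1 to compound 2 corresponds to the change (methyl in place of hydrogen on a saturated chain carbon, two bonds along the chain from an aromatic nitrogen), and because the limit of > 50000 nM in this assay, at which 2 of the 3 values shown sit, its size cannot be read. Compound 4 `CCCCCC(CCO)n1cnc2c(Cl)nc(F)nc21` is the unmeasured homologue of compound 3, arrived at by methyl in place of hydrogen on a saturated chain carbon, five bonds along the chain from an aromatic nitrogen. This is the same kind of change as from compound 1 to compound 2, but the place differs: two bonds along the chain from an aromatic nitrogen in the earlier pair, five bonds along the chain from an aromatic nitrogen here. With the earlier step unreadable, nothing measured sets its size, so the estimated step is taken as a 1.4-fold lower number from compound 3 to compound 4 (0.13 log units; within the scatter), within scatter. Compound 4 is therefore estimated at 10000 nM, with a range from 3000 nM to 30000 nM.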

Compound 4, half-maximal inhibitory concentration: 8660 nM
Compound 4: the middle estimate sits 1.2-fold (0.06 log units) above what was measured; measured number inside the range.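

On the core of compound 3, adding the methyl on a saturated chain carbon, five bonds along the chain from an aromatic nitrogen, gives a 1.6-fold lower number from compound 3 to compound 4 (0.19 log units; within the scatter), so on this core the change leaves the two values indistinguishable in this assay. For the compounds shown here, the same kind of change on the core of compound 1, two bonds along the chain from an aromatic nitrogen, cannot be read, because neither of the two values there is a number: the limit of > 50000 nM in this assay, at which 2 of the 4 values shown sit. The series therefore holds only one readable step, which gives no size to compare across cores, and the place of the change differs as well, so these data neither support nor contradict carrying the change from one core to the other.

No chain shown appears on both cores, so the difference between the cores remains separate and unresolved. Going by these compounds, how a longer chain, or an amine in place of the hydroxyl, would read in this assay also stays open.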